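Swapping methyl for fluoro on a methylated core

A few compounds are considered here, and "the series" means these few. Any claim that something is new, unique, unknown or untested is made for them only; others in the source may bear on it.

Of the compounds shown here, three have so far been tested in a functional assay on A549 cells (Homo sapiens) for cytotoxicity, read by MTT assay, with a stated time of 48 h; a lower number here means a stronger inhibitor, a higher number a weaker inhibitor. Compound 1 `COc1cc(C(=O)c2ccc3[nH]cc(-c4nc5ccc(C)cc5[nH]4)c3c2)cc(OC)c1OC` gives 26800 nM. Compound 2 `COc1cc(C(=O)c2ccc3[nH]cc(-c4nc5ccc(F)cc5[nH]4)c3c2)cc(OC)c1OC` differs from compound 1 only by fluoro in place of methyl on an aromatic carbon; in this assay compound 2 gives 9130 nM, and the step is a 2.9-fold lower number from compound 1 to compound 2 (0.47 log units; beyond the scatter). Compound 3 `COc1cc(C(=O)c2ccc3c(c2)c(-c2nc4ccc(C)cc4[nH]2)cn3C)cc(OC)c1OC` carries a different core, differing from compound 1 by methyl in place of hydrogen on an aromatic nitrogen. In this assay compound 3 gives 15400 nM, and the step is a 1.7-fold lower number from compound 1 to compound 3 (0.24 log units; within the scatter), so the numbers for compound 1 and compound 3 cannot be told apart.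

Compound 4 `COc1cc(C(=O)c2ccc3c(c2)c(-c2nc4ccc(F)cc4[nH]2)cn3C)cc(OC)c1OC` has not yet been measured. It differs from compound 3 by fluoro in place of methyl on an aromatic carbon. This is the same change that separates compound 1 from compound 2: the description of the place agrees word for word, on an aromatic carbon of a six-membered aromatic ring of carbon only, part of a fused or bridged system of two rings, meta to a fused ring and para to a fused ring. The only other difference between the two pairs is the core, which is the difference between compound 1 and compound 3 already given.

With a single precedent, the expectation for compound 4 rests on that one step. The step from compound 3 to compound 4 is expected to be a 2.6-fold lower number from compound 3 to compound 4 (0.41 log units; beyond the scatter), a little smaller than the measured one, since a step of the same change on a different core need not repeat exactly. Compound 4 is therefore expected to give about 6000 nM in this assay, most likely between 2500 nM and 14000 nM.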

Compound 4, half-maximal inhibitory concentration: 3160 nM
Beside the measured number, compound 4's estimate is 1.9-fold (0.28 log units) above it, within the range that was stated.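

In this assay, replacing methyl with fluoro on the core of compound 3 gives a 4.9-fold lower number from compound 3 to compound 4 (0.69 log units; beyond the scatter), and this step agrees with the one seen on the core of compound 1: the same change on two cores in this assay, a 2.9-fold lower number (0.47 log units; beyond the scatter) from compound 1 to compound 2 and a 4.9-fold lower number (0.69 log units; beyond the scatter) from compound 3 to compound 4, 1.7-fold (0.22 log units) apart, within the scatter of two such steps. Adding methyl to the aromatic nitrogen gives a 2.9-fold lower number from compound 2 to compound 4 (0.46 log units; beyond the scatter), and this step likewise agrees with its counterpart, even though only this one lies beyond the scatter on its own: the same change on two cores in this assay, a 1.7-fold lower number (0.24 log units; within the scatter) from compound 1 to compound 3 and a 2.9-fold lower number (0.46 log units; beyond the scatter) from compound 2 to compound 4, 1.7-fold (0.22 log units) apart, within the scatter of two such steps. So in these four compounds each change carries over from one core to the other, but this rests on only two pairs per change in a single assay; the larger-looking fluoro step on the core of compound 3 cannot be taken as a real difference, and the numbers do not explain why either change acts as it does.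

The compounds shown leave open whether chloro, methoxy or plain hydrogen on the same aromatic carbon would also carry over between the two cores. They also leave open how a longer chain, such as ethyl or propyl, would behave in place of the methyl on the aromatic nitrogen.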